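Acid dissociation after shortening a side chain

A few compounds are considered here, and "the series" means these few. Any claim that something is new, unique, unknown or untested is made for them only; others in the source may bear on it.

In a physicochemical assay for acid dissociation, read by spectrophotometry, compound 1 `Cc1cc(=O)c(O)c(CN2CCCCC2)n1C` gives 6.98, while compound 2 `O=c1cc(CN2CCCCC2)n(CCN2CCCCC2)cc1O` gives 7.6. Compound 2 therefore stands highest of the two measured compounds, and the gap between them lies beyond the scatter. Compound 3 `Cn1cc(O)c(=O)cc1CN1CCCCC1` has not yet been measured. Its structure departs from that of compound 2 by one change: hydrogen in place of (piperidin-1-yl)methyl on a saturated chain carbon bound to an aromatic nitrogen, with hydrogen in place of (piperidin-1-yl)methyl on a saturated chain carbon bound to an aromatic nitrogen. For the measured compounds named here, no measured pair isolates this change, so the expectation rests on thin evidence. Compound 1 also lacks this (piperidin-1-yl)methyl and gives 6.98, which points to a lower number. A modest downward step in this assay, about the size of the scatter, is expected, estimated as a number 0.30 log units lower from compound 2 to compound 3 (within the scatter). For compound 3 the estimated value is 7.3, with an expected range from 6.8 to 7.8.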

Compound 3, acid dissociation constant: 6.72
Compound 3: the middle estimate sits 0.58 log units above what was measured; measured number below the stated range.
By their numbers in this assay, from the lowest: compounds 3 and 1 (each within the scatter of the next); then compound 2.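

Replacing the (piperidin-1-yl)methyl with hydrogen on a saturated chain carbon bound to an aromatic nitrogen now has a direct measurement in this assay, where the read-out moves by a number 0.88 log units lower from compound 2 to compound 3 (beyond the scatter). Compounds 1 and 2 differ in more than one place and could not isolate this change, whereas this single pair shows that the read-out responds to this substituent by more than the usual scatter. Nothing measured here bears on why the number moves.

A single pair cannot separate the contribution of the six-membered non-aromatic ring from that of the whole substituent. It also leaves open whether a morpholine, a dimethylamine, a carboxylic acid or a longer chain at this place would shift the number as far.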